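Vero cytotoxicity of nitrofuran chalcones: piperazine replacing iodo

The source may hold more compounds than are shown below. What is called first, only, known or untested is meant among the compounds shown, and "the series" means these compounds.

Compound 1, `O=C(/C=C/c1ccc([N+](=O)[O-])o1)c1ccc(I)cc1`: in an ADME assay on Vero cells (Chlorocebus sabaeus) for cytotoxicity, read by resazurin assay, with a stated time of 72 h (on this read-out lower numbers stand for higher toxicity in this test and higher numbers for lower toxicity in this test), compound 1 gives > 100000 nM, which is a limit of the assay and not a number.
Compound 2, `O=C(/C=C/c1ccc([N+](=O)[O-])s1)c1ccc(-n2ccnc2)cc1`: in this assay compound 2 gives 42700 nM.
Compound 3, `COc1ccc(/C=C/C(=O)c2cccc(I)c2)cc1`: in this assay compound 3 gives > 100000 nM, again a limit of the assay.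

Compound 1 thus stands at the limit of this assay; it has no number of its own, and the same is true of compound 3, so that only compound 2 yields a measured value in this set (the limit of > 100000 nM in this assay, at which 2 of the 3 values shown sit). For the measured compounds named here, no pair of these three compounds differs in one place only, and no step between measured compounds can be counted.

The compound now in question is compound 4, `O=C(/C=C/c1ccc([N+](=O)[O-])o1)c1ccc(N2CCNCC2)cc1`. It arises from compound 1 by piperazin-1-yl in place of iodo on an aromatic carbon, a change in which piperazin-1-yl replaces iodo on an aromatic carbon. Going by the values given here, nothing among the measured compounds shows what this exchange does in this assay; compound 2, the only one with a number, carries a different five-membered ring and a different aromatic substituent, so it gives no direct guide.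

Since compound 1 sits at the limit, any step from compound 1 to compound 4 is expected to be either none beyond the scatter or toward lower numbers, as an at least 1.6-fold lower number from compound 1 to compound 4 (0.22 log units; that floor lies within the scatter). Compound 4 is therefore expected to give about 60000 nM in this assay, with a range from 20000 nM to 150000 nM, and with a fair chance that the assay again reports only a limit.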

Compound 4, half-maximal cytotoxic concentration: > 100000 nM
Compound 4: no number, only a limit; the forecaster's own chance of this, stated with the estimate: 40%; middle value at least 1.6-fold (0.22 log units) from the limit.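

In this assay, compound 1 and compound 4 both stop at a limit of the assay, so no step between them can be read: the limit of > 100000 nM in this assay, at which 3 of the 4 values shown sit.

The compounds shown leave open where the true values of compound 1 and compound 4 lie, and so whether piperazin-1-yl in place of iodo on an aromatic carbon changes this read-out at all.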